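The source may hold more compounds than are shown below. What is called first, only, known or untested is meant among the compounds shown, and "the series" means these compounds.

Values in a functional assay on HeLa cells (Homo sapiens) for inhibition, read by MTT assay, with a stated time of 48 h (a lower number here means a stronger inhibitor of growth, a higher number a weaker inhibitor of growth), so far:
- compound 1 `Cn1cc(C2CC(c3ccccc3)=NN2C(=O)c2cccnc2)c2ccccc21` gives > 10000 nM (a limit of the assay, not a number)
- compound 2 `COc1ccc(C(=O)N2N=C(c3ccccc3)CC2c2cn(C)c3ccccc23)cn1` gives 3980 nM 
- compound 3 `Cc1ccc(C(=O)N2N=C(c3ccccc3)CC2c2cn(C)c3ccccc23)cn1` gives 2390 nM 

For the measured compounds named here, compound 3 and compound 2 are the only two with an actual number, and they cannot be told apart (a 1.7-fold lower number from compound 2 to compound 3 (0.22 log units; within the scatter)).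

The next compound is compound 4 `Cn1cc(C2CC(c3ccccc3)=NN2C(=O)c2ccncc2)c2ccccc21`, with pyridin-4-yl in place of 6-methylpyridin-3-yl on a carbonyl carbon. The change takes away the methyl group of compound 3, so the most relevant measured step is an at least 4.1-fold lower number from compound 1 to compound 3 (0.62 log units; beyond the scatter), which has methyl in place of hydrogen on an aromatic carbon. The step of an at least 2.5-fold lower number from compound 1 to compound 2 (0.40 log units; beyond the scatter) is similar in kind, with methoxy in place of hydrogen. On these data alone, both start from a limit, so their full size stays open. Going by the values given here, no measured compound carries pyridin-4-yl, so that part of the change has no direct measure.

Given an at least 4.1-fold lower number from compound 1 to compound 3 (0.62 log units; beyond the scatter), a move towards a higher number in this assay is expected, with the value landing near the limit. The expected step is a 3.3-fold higher number from compound 3 to compound 4 (0.52 log units; beyond the scatter) (an estimate). For compound 4 the estimated value is 8000 nM, with an expected range from 3500 nM to 20000 nM (a report of a limit alone would not be a surprise).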

Compound 4, concentration for 50% growth inhibition: 590 nM
For compound 4 the middle estimate is 14-fold (1.13 log units) above the measured one; the measured number lies below the stated range.
By their numbers in this assay, from the lowest: compound 4; then compounds 3 and 2 (each within the scatter of the next). At a limit, above all of these: compound 1.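

In this assay the group on the carbonyl carbon proves able to move the number well past what the methyl and methoxy groups did, and pyridin-4-yl does so with neither of them present (a 4.1-fold lower number from compound 3 to compound 4 (0.61 log units; beyond the scatter) and a 6.7-fold lower number from compound 2 to compound 4 (0.83 log units; beyond the scatter)). Among the compounds shown, a substituent on pyridin-3-yl is therefore not needed for a measurable number, and compound 4 is the only one whose steps to all the others lie beyond the scatter. The swap of pyridin-3-yl for pyridin-4-yl alone gives the largest step in the set (an at least 16-fold lower number from compound 1 to compound 4 (1.22 log units; beyond the scatter)), and compound 1 gives > 10000 nM, which is a limit of the assay and not a number, so the true size of that step stays open: the limit of > 10000 nM in this assay, at which 1 of the 4 values shown sits.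

On these data alone, whether a methyl or methoxy group on pyridin-4-yl would lower the number further remains open, as does the reading for pyridin-2-yl, a plain phenyl ring or an amine on the ring. As far as these compounds go, the shared core is also constant across all four compounds, so it is unknown whether the preference for pyridin-4-yl would hold with another group in place of its phenyl or its indole methyl.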